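The source may report more compounds than this note shows. Statements on the series, on what has been measured and on what is new or still open speak of the compounds shown alone.

Compound 1 `NC/C=C/COc1ccccc1` and compound 2 `CC(C)(C)c1ccc(OC/C(F)=C\CN)cc1` were both tested in an assay on isolated protein for inhibition of Amine oxidase [copper-containing] 3 (Homo sapiens), read by Amplex Red; a higher number here means a weaker inhibitor, a lower number a stronger inhibitor. In that test compound 1 gives 82000 nM, while compound 2 gives 210 nM, the lowest of the two numbers, and the gap between them lies well beyond the usual scatter. Compound 3 `NC/C=C(/F)COc1ccc(C(F)(F)F)cc1` differs from compound 2 in a single place: trifluoromethyl in place of tert-butyl on an aromatic carbon, a trifluoromethyl in place of tert-butyl on an aromatic carbon. Going by the values given here, no measured pair shows what such a swap does, so the step from compound 2 to compound 3 is expected to be modest, a 1.9-fold higher number from compound 2 to compound 3 (0.28 log units; within the scatter), leaning toward a weaker inhibitor. Compound 3 is estimated at 400 nM, within 100 nM to 1600 nM.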

Compound 3, half-maximal inhibitory concentration: 40 nM
Compound 3: the middle estimate sits 10-fold (1.00 log units) above what was measured; the measured number lies below the stated range.
By their numbers in this assay, from the lowest: compound 3; then compound 2; then compound 1.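

Trifluoromethyl in place of tert-butyl on this aromatic carbon gives a 5.3-fold lower number from compound 2 to compound 3 (0.72 log units; beyond the scatter), which means a stronger inhibitor. The two groups have the same count of 4 heavy atoms and neither has hydrogen-bond donors or acceptors, yet this position still separates them beyond the scatter. No measured evidence accompanies this result to explain the gain.

From the compounds shown here alone, it remains open how a chlorine atom, a methoxy group or a nitrile would fare on this aromatic carbon. Also open is what the fluorine on the chain contributes alone: no pair of compounds shown differs only there.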